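A few compounds are considered here, and "the series" means these few. Any claim that something is new, unique, unknown or untested is made for them only; others in the source may bear on it.

Compound 2 `COc1ccc(-n2nc(C(=O)Nc3ccc(Oc4ccncc4-c4cccnc4)c(F)c3)c3ccccc3c2=O)cc1` and compound 1 `COc1ccc(-n2nc(C(=O)Nc3ccc(Oc4ccncc4-c4cccnc4)c(F)c3)c(=O)n(C)c2=O)c(OC)c1` share a core and differ in the ring fused to it and in the substitution of the aryl group on the core. In a functional assay on MKN-45 cells (Homo sapiens) for cytotoxicity, read by MTT assay, with a stated time of 72 h (a higher number here means a weaker inhibitor, a lower number a stronger inhibitor), compound 2 gives 740 nM, the lower of the two numbers recorded; compound 1 gives 2820 nM, so compound 2 is the stronger inhibitor of the pair by a gap beyond the scatter. Compound 3 `O=C(Nc1ccc(Oc2ccncc2-c2cccnc2)c(F)c1)c1nn(-c2ccc(F)cc2)c(=O)c2ccccc12` keeps the core of compound 2 with one change, (fluoro in place of methoxy on an aromatic carbon), in words fluoro in place of methoxy on an aromatic carbon. Among the measured compounds shown here, no measured pair shows this exact change, so the step from compound 2 to compound 3 is expected to be small, with no clear direction beyond the scatter, as a 1.0-fold higher number from compound 2 to compound 3 (0.01 log units; within the scatter). Compound 3 is therefore estimated to give about 750 nM in this assay, within a range of 300 nM to 1800 nM.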

Compound 3, half-maximal inhibitory concentration: 320 nM
Estimate against measurement, compound 3: 2.3-fold (0.37 log units) above; measured number inside the range.
By their numbers in this assay, from the lowest: compound 3; then compound 2; then compound 1.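

In this assay, replacing 4-methoxyphenyl with 4-fluorophenyl on the shared core gives a 2.3-fold lower number from compound 2 to compound 3 (0.36 log units; beyond the scatter), a modest step. Among the compounds shown here, this is the first comparison here that changes only one place, and it shows that the group para to a large group on this ring affects the number in these cells and that the methoxy is not needed to keep the activity of compound 2. Nothing available here bears on why the number falls with this change.

The compounds shown leave open whether fluoro itself matters at this position, or whether a hydrogen, chloro, trifluoromethyl or an amine there would give a similar number. They also leave open whether the same change would lower the number on the core of compound 1.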